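Replacing the Chain End of a Leukotriene Receptor Ligand

The compounds below may be only part of what the source reports. "The series", "measured", "known", "first", "only" and "open" are said of these compounds alone.

Three compounds have been measured in an assay on isolated protein for inhibition of leukotriene B4 receptor 1 (Homo sapiens), tested at 10 uM; on this read-out higher numbers stand for more inhibition at the one concentration tested (going by the name of the read-out) and lower numbers for less inhibition:

Compound 1 `C=CCc1cc(C(C)=O)c(O)cc1OCCCC#N`: 47%
Compound 2 `C=CCCCCOc1cc(O)c(C(C)=O)cc1CC=C`: 73%
Compound 3 `C#CCCCCOc1cc(O)c(C(C)=O)cc1CC=C`: 74%

Compound 3 stands highest of the three numbers, but its lead over compound 2 is only a number 1 percentage points higher from compound 2 to compound 3 (within the scatter), which lies within the scatter, so the two cannot be told apart. Compound 1 sits clearly lower, the gap being a number 27 percentage points higher from compound 1 to compound 3 (beyond the scatter).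

Compound 4 `C=CCc1cc(C(C)=O)c(O)cc1OCCCCCC(=O)OC` has not yet been measured. It differs from compound 3 as follows: (methoxycarbonyl)methyl in place of ethynyl on a saturated chain carbon, four bonds along the chain from an oxygen on an aromatic ring.

Going by the values given here, two measured steps bear on this change. Putting allyl in place of cyano gave a number 26 percentage points higher from compound 1 to compound 2 (beyond the scatter), and putting propargyl in place of cyano gave a number 27 percentage points higher from compound 1 to compound 3 (beyond the scatter); both replaced a chain end carrying a hetero atom with a plain hydrocarbon end and raised inhibition. The third step, a number 1 percentage points higher from compound 2 to compound 3 (within the scatter), shows that swapping one hydrocarbon end for another changes nothing. Among the compounds with values here, compound 4 runs the first two steps in reverse, bringing a group with two hydrogen-bond acceptors to the chain end, so a drop in this assay is expected, of roughly the size seen there.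

Compound 4 is therefore estimated at 52%, within a range of 32% to 72%, which means an expected step of a number 22 percentage points lower from compound 3 to compound 4 (beyond the scatter).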

Compound 4, a percentage reported as inhibition, at one concentration (the size of the read-out at that concentration, not a potency): 106%
For compound 4 the middle estimate is 54 percentage points below the measured one, and the stated range ends below it.
By their numbers in this assay, from the lowest: compound 1; then compounds 2 and 3 (each within the scatter of the next); then compound 4.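

In this assay, going by these compounds alone, the earlier compounds suggested that a plain hydrocarbon chain end was the better choice, but the ester-bearing end of compound 4 overturns that reading. (Methoxycarbonyl)methyl in place of ethynyl gives a number 32 percentage points higher from compound 3 to compound 4 (beyond the scatter), and in place of vinyl it gives a number 33 percentage points higher from compound 2 to compound 4 (beyond the scatter), so a chain end carrying hydrogen-bond acceptors can outdo both hydrocarbon ends. Against the nitrile, 2-(methoxycarbonyl)ethyl in place of cyano gives a number 59 percentage points higher from compound 1 to compound 4 (beyond the scatter), which shows that the two chain ends containing hetero atoms sit at opposite extremes of this small series, and that the presence of hetero atoms alone does not predict a low number; what lies behind this rise has no measurement here to explain it.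

As far as these compounds go, compound 4 is the only ester among the four compounds, so it remains open whether the gain needs the whole methyl ester or would survive with a carboxylic acid or a primary amide at the same chain end. From the compounds shown here alone, it also remains open how the result depends on the distance from the ring oxygen, which a shorter or longer chain ending in the same methyl ester would test.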